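A few compounds are considered here, and "the series" means these few. Any claim that something is new, unique, unknown or untested is made for them only; others in the source may bear on it.

Measured so far:
Compound 1, `CCCNc1nc2c(NC3CCCC3)ncnc2n1[C@@H]1O[C@H](CO)[C@@H](O)[C@H]1O`: 97 nM
Compound 2, `CCNc1nc2c(SCc3ccccc3)ncnc2n1C1O[C@H](CO)[C@@H](O)[C@H]1O`: 9.5 nM

In an assay on cell membranes for binding affinity to Equilibrative nucleoside transporter 1 (Homo sapiens) (on this read-out higher numbers stand for weaker inhibition and lower numbers for stronger inhibition), compound 2 gives 9.5 nM, the lowest of the two numbers. Its nearest neighbour, compound 1, gives 97 nM in this assay, a higher number that lies beyond the scatter; the two compounds differ in more than one place, so their gap cannot be ascribed to any single change.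

Compound 3, `CCCCNc1nc2c(SCc3ccccc3)ncnc2n1C1O[C@H](CO)[C@@H](O)[C@H]1O`, is not yet measured. It differs from compound 2 by ethyl in place of hydrogen on a saturated chain carbon, two bonds along the chain from a nitrogen on an aromatic ring, that is, the ethylamino group of compound 2 becomes a butylamino group. Among the measured compounds shown here, no pair of measured compounds that differ in one place is available, so the size of such a step cannot be read from the data. With no comparison to lean on, the step from compound 2 to compound 3 is expected to be small, a 1.3-fold higher number from compound 2 to compound 3 (0.10 log units; within the scatter), most likely within the scatter and in no fixed direction. Compound 3 is therefore estimated at 12 nM in this assay, within a range of 4 nM to 36 nM.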

Compound 3, inhibition constant: 5.4 nM
Compound 3: middle estimate off by 2.2-fold (0.35 log units), on the high side, within the range that was stated.
By their numbers in this assay, from the lowest: compounds 3 and 2 (each within the scatter of the next); then compound 1.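

Among the compounds shown here, the step from ethylamino to butylamino is the first comparison that differs in one place, and in this assay it reads as a 1.8-fold lower number from compound 2 to compound 3 (0.25 log units; within the scatter). Adding ethyl on this saturated chain carbon, two bonds along the chain from a nitrogen on an aromatic ring, therefore brings no change in binding that can be told apart from the scatter, so over this one step the read-out does not respond to the added chain length. Nothing measured on these compounds accounts for this outcome, so the reason for it stays unknown.

One step between two chain lengths cannot show how far this insensitivity extends, and whether a longer chain such as hexyl, or a chain ending in an amine, a hydroxyl or a carboxylic acid, would leave the number in this assay equally unmoved remains an open question. Compound 1 still differs from both of these compounds in more than one place, so the part that the chain at this position plays in its gap to them cannot be separated out.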